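The source may hold more compounds than are shown below. What is called first, only, known or untested is meant among the compounds shown, and "the series" means these compounds.

Of the compounds shown here, two have been measured in a physicochemical assay for solubility (a lower number here means a less soluble compound, a higher number a more soluble compound), so far. Compound 1 `CNC(=O)c1cc(C(=O)NC2CC2)cn(Cc2ccc(C)cc2)c1=O` gives 24 ug/mL in this assay, the lower of the two numbers. Compound 2 `CNC(=O)c1cccn(Cc2ccccc2)c1=O` gives 78 ug/mL in this assay, a higher number than that of compound 1 by more than the usual scatter; the two structures differ in several places at once, however, so the gap between them cannot be tied to any single change.

The next compound, compound 3 `CNC(=O)c1cc(C(=O)NC2CC2)cn(CC2CCCOC2)c1=O`, differs from compound 1 in one place only: oxan-3-yl in place of 4-methylphenyl on a saturated chain carbon bound to an aromatic nitrogen A six-membered aromatic ring of carbon only leaves, and a six-membered non-aromatic ring with one hetero atom, carrying one hydrogen-bond acceptor, enters, on a saturated chain carbon bound to an aromatic nitrogen.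

For the measured compounds named here, no measured pair shows this kind of change, so its effect in this assay has to be estimated from the change alone. A moderate rise is expected, beyond the usual scatter, rather than a fall or no change. The step expected is a 2.9-fold higher number from compound 1 to compound 3 (0.46 log units; beyond the scatter). Compound 3 is therefore estimated at 70 ug/mL, with a likely range from 25 ug/mL to 200 ug/mL.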

Compound 3, solubility: >= 131 ug/mL
Compound 3: no number, only a limit; the forecaster's own chance of this, stated with the estimate: 5%; middle value at least 1.8-fold (0.27 log units) away from the limit.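

For the compounds shown here, compound 3 is the first case in which only the group on the saturated chain carbon bound to an aromatic nitrogen changes, so a gap in this assay can now be tied to one place: oxan-3-yl in place of 4-methylphenyl brings an at least 5.4-fold higher number from compound 1 to compound 3 (0.73 log units; beyond the scatter). The earlier pair could not show this, since compound 1 and compound 2 differ in several places at once. Compound 3 gives >= 131 ug/mL, which is a limit of the assay and not a number, so the step marks only a minimum and its full size stays unknown: the limit of >= 131 ug/mL in this assay, at which 1 of the 3 values shown sits.

This single change removes an aromatic ring and brings in a non-aromatic ring with a hydrogen-bond acceptor, and the compounds shown cannot tell whether the loss of the aromatic ring or the arrival of the ring oxygen accounts for the step. A cyclohexyl group on the same chain carbon would have a saturated ring without the oxygen, and a group carrying an amine would show how a quite different kind of substituent reads at this place.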